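This account rests on a few compounds, and the source may have more. Where it says the series, first, only, none or still open, it means among the compounds named here.

Three lactone and lactam analogues share a styryl-substituted six-membered ring, and their growth inhibition was measured in a functional assay on U-251 cells (Homo sapiens) for inhibition, read by sulforhodamine B assay, with a stated time of 48 h; on this read-out higher numbers stand for weaker inhibition of growth and lower numbers for stronger inhibition of growth. Compound 1, `COc1ccc(/C=C/C2CC=CC(=O)O2)cc1OC`, gives 23.9 uM in this assay. Compound 2, `COc1cc(/C=C/C2CC=CC(=O)O2)cc(OC)c1OC`, gives 25.1 uM in this assay. The change from compound 1 to compound 2 is methoxy in place of hydrogen on an aromatic carbon, and it made a step of a 1.1-fold higher number from compound 1 to compound 2 (0.02 log units; within the scatter). Compound 3, `COc1ccc(/C=C/C2CC=CC(=O)N2)cc1`, gives 981 uM in this assay, the highest number of the three, a gap to compound 2 and to compound 1 that is beyond the scatter. The difference between the core of compound 3 and the core of compound 1 is not broken down here.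

Compound 4, `COc1ccc(/C=C/C2CC=CC(=O)N2)cc1OC`, has not yet been measured in this assay. It differs from compound 3 by methoxy in place of hydrogen on an aromatic carbon. This is the same kind of change as that from compound 1 to compound 2, though the surroundings are not identical: in compound 2 the entering methoxy is also meta to a methoxy group, whereas in compound 4 it is only ortho to a methoxy group and meta to a group of 9 heavy atoms. Because a 1.1-fold higher number from compound 1 to compound 2 (0.02 log units; within the scatter) lay within the scatter, the step from compound 3 to compound 4 is expected to be about a 1.1-fold lower number from compound 3 to compound 4 (0.04 log units; within the scatter). Compound 4 is therefore estimated to give 900 uM in this assay, with a likely range from 400 uM to 2000 uM.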

Compound 4, concentration for growth inhibition (reported as GI): > 964 uM
Compound 4 gave a limit, no number; the forecaster's own chance of this, stated with the estimate: 25%; middle value at least 1.0-fold (0.02 log units) from the limit.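

Compound 4 gave a limit in this assay and not a number, so the step from compound 3 to compound 4 cannot be read: the limit of > 964 uM in this assay, at which 1 of the 4 values shown sits.

The compounds shown leave open whether methoxy in place of hydrogen on an aromatic carbon does on the core of compound 3 what it did on the core of compound 1, where the change was a 1.1-fold higher number from compound 1 to compound 2 (0.02 log units; within the scatter).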